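A few compounds are considered here, and "the series" means these few. Any claim that something is new, unique, unknown or untested is made for them only; others in the source may bear on it.

Measured in a functional assay on the whole organism (heart) with Rattus norvegicus as the target; a higher number here means that more compound is needed for the effect, a lower number that less compound is needed:

compound 1 `CC(=O)/C(=C\c1ccccc1)Oc1ccccc1OCC(O)CNC(C)(C)C`: 1.9 mg/kg
compound 2 `CC(=O)/C(=C\c1ccccc1)Oc1ccccc1OCCCNC(C)(C)C`: 1.5 mg/kg
compound 3 `CC(=O)/C(=C\c1ccccc1)Oc1ccccc1OCCCN(C)C`: 0.37 mg/kg

Compound 3, at 0.37 mg/kg, has the lowest number of the three, and its gaps to both others lie beyond the scatter. Compound 4 `CC(=O)/C(=C\c1ccccc1)Oc1ccccc1OCCCN(C(C)C)C(C)C` keeps the rest of compound 3 and alters only the amino group: diisopropylamino in place of dimethylamino on a saturated chain carbon, three bonds along the chain from an oxygen on an aromatic ring. The new group, diisopropylamino, has not been measured on this scaffold, so the evidence is indirect.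

The closest guide is a 4.1-fold lower number from compound 2 to compound 3 (0.61 log units; beyond the scatter), a modest step with dimethylamino in place of (tert-butyl)amino. Read in reverse, it suggests a higher number when dimethylamino gives way to a larger amino group, although this rests on a single pair. The step of a 5.1-fold lower number from compound 1 to compound 3 (0.71 log units; beyond the scatter) points the same way, but it also removes the hydroxy. Removing the hydroxy alone gave a 1.3-fold lower number from compound 1 to compound 2 (0.10 log units; within the scatter), which is within the scatter.

The expected change is a 2.4-fold higher number from compound 3 to compound 4 (0.39 log units; beyond the scatter), an estimated modest rise in this assay. For compound 4 the estimated value is 0.9 mg/kg, with an expected range from 0.3 mg/kg to 2.5 mg/kg on this measure.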

Compound 4, dose for half-maximal effect: 0.1 mg/kg
The estimate for compound 4 lay 9.0-fold (0.95 log units) above the measured number; measured number below the stated range.
By their numbers in this assay, from the lowest: compound 4; then compound 3; then compounds 2 and 1 (each within the scatter of the next).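

In this assay, going by these compounds alone, exchanging dimethylamino for diisopropylamino gave a 3.7-fold lower number from compound 3 to compound 4 (0.57 log units; beyond the scatter) rather than a rise, so this position does not simply penalise a larger amino group, and the single earlier pair with (tert-butyl)amino did not predict this change. The contrast with (tert-butyl)amino at the same position is much wider, with a 15-fold lower number from compound 2 to compound 4 (1.18 log units; beyond the scatter) as a large step, and a 19-fold lower number from compound 1 to compound 4 (1.28 log units; beyond the scatter) as a large step that also removes the hydroxy. Nothing in the data explains why diisopropylamino needs less compound than the other amino groups.

From the compounds shown here alone, it remains open how groups such as diethylamino or a ring amine like piperidine would compare at this position. A longer chain, or the hydroxy restored alongside diisopropylamino, is equally untested in the compounds shown here.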